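Dropping One Methoxy Group: What the Numbers Suggest

The source may hold more compounds than are shown below. What is called first, only, known or untested is meant among the compounds shown, and "the series" means these compounds.

Of the compounds shown here, three built on a shared core have been tested in a functional assay on HCC 2998 cells (Homo sapiens) for inhibition, read by sulforhodamine B assay, with a stated time of 48 h; on this read-out lower numbers stand for stronger inhibition of growth and higher numbers for weaker inhibition of growth. Compound 1 `COc1ccc(-c2cc(/C=C/C(=O)c3ccc(N)cc3)[nH]n2)cc1` gives 1830 nM. Compound 2 `COc1cc(-c2cc(/C=C/C(=O)c3ccc(N)cc3)[nH]n2)cc(OC)c1OC` gives 2010 nM. Compound 3 `COc1ccc(C(=O)/C=C/c2cc(-c3cc(OC)c(OC)c(OC)c3)n[nH]2)cc1` gives 1780 nM. Compound 2 stands at the top of these three numbers, yet its gaps to compound 1 and to compound 3 both lie within the scatter, so the three cannot be told apart. Going by the values given here, the only step between compounds that differ in one place is a 1.1-fold lower number from compound 2 to compound 3 (0.05 log units; within the scatter), which likewise stays within the scatter.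

Compound 4 `COc1ccc(-c2cc(/C=C/C(=O)c3ccc(N)cc3)[nH]n2)cc1OC` has not yet been measured. Its change from compound 2 is hydrogen in place of methoxy on an aromatic carbon. Among the compounds with values here, no measured step removes a methoxy group, so the step from compound 2 to compound 3 bears on it only loosely, by showing that one change on this core left this assay unmoved. Compound 1 carries a single methoxy group on that ring and compound 2 carries three, and both return numbers within the scatter of each other, so the count of methoxy groups seems to matter little here. Compound 4 is therefore expected to show a 1.1-fold lower number from compound 2 to compound 4 (0.02 log units; within the scatter), meaning no step beyond the scatter. The estimate for compound 4 is 1900 nM, with a range from 900 nM to 4000 nM.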

Compound 4, concentration for 50% growth inhibition: 2020 nM
Compound 4: middle estimate off by 1.1-fold (0.03 log units), on the low side, within the range that was stated.
By their numbers in this assay, from the lowest: compounds 3, 1, 2 and 4 (each within the scatter of the next).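

In this assay, replacing one methoxy group of compound 2 with hydrogen, on the carbon that is meta to a large group, gives a 1.0-fold higher number from compound 2 to compound 4 (0.00 log units; within the scatter), and the listed step in the other direction, methoxy in place of hydrogen, gives a 1.1-fold higher number from compound 1 to compound 4 (0.04 log units; within the scatter) for the same ring. Going by these compounds alone, until now, no step between measured compounds had changed a methoxy group on this ring in one place alone; these two steps do, and both show that hydrogen and methoxy on this ring cannot be told apart on this read-out, whichever compound the comparison starts from. Nothing available accounts for why this change leaves the number unmoved.

The only groups compared at this carbon are methoxy and hydrogen, so the compounds shown leave open whether a hydroxyl group, a fluorine atom or a longer chain such as ethoxy would also stay within the scatter. They also leave open whether removing a methoxy group would stay within the scatter on the core of compound 3, where a methoxy group stands in place of the amino group.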